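The source may report more compounds than this note shows. Statements on the series, on what has been measured and on what is new or still open speak of the compounds shown alone.

Compound 1, with the structure `O=c1n(Cc2cc3cnccc3n2CCCCF)c2cnccc2n1C1CC1`, is the starting point of this account. In an ADME assay on HeLa cells (Homo sapiens) for cytotoxicity, read by ATP content, with a stated time of 3 days (a lower number here means that less compound is tolerated, a higher number that more compound is tolerated), compound 1 gives > 50000 nM, which is a limit of the assay and not a number. Compound 2, with the structure `N#CCCCn1c(Cn2c(=O)n(C3CC3)c3ccncc32)nc2nc(Cl)ccc21`, belongs to the same series. In this assay compound 2 gives > 50000 nM, again a limit rather than a number. Where compound 1 stands is therefore only known as far as the limit of > 50000 nM in this assay, at which 2 of the 2 values shown sit, and no step between measured compounds is available to calibrate the size of a structural change.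

The unmeasured compound 3 has the structure `O=c1n(Cc2cc3cnccc3n2CCCC(F)(F)F)c2cnccc2n1C1CC1`. Compared with compound 1 it carries trifluoromethyl in place of fluoromethyl on a saturated chain carbon, three bonds along the chain from an aromatic nitrogen. Within the data shown here, nothing among the measured compounds bears on this change, so the expectation rests on the limit of compound 1 alone.

The step from compound 1 to compound 3 is expected to be a step that the limit leaves unreadable from compound 1 to compound 3, that is none beyond the scatter. Compound 3 is accordingly estimated at 60000 nM, within a range from 30000 nM to 150000 nM, and it is expected that this assay will again report only a limit for compound 3.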

Compound 3, half-maximal cytotoxic concentration: > 50000 nM
Compound 3: only a limit was reported (the forecaster's own chance of this, stated with the estimate: 85%); the middle value does not contradict the limit.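

In this assay compound 3 gives > 50000 nM and this is a limit of the assay, not a number. Among these compounds, compound 1 also stands at a limit, so no step between compound 1 and compound 3 can be read. The compounds shown leave open at what concentration any of them would become cytotoxic to these cells.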